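A Cyano Group Added to Compound 2

This account rests on a few compounds, and the source may have more. Where it says the series, first, only, none or still open, it means among the compounds named here.

Compound 1 `Cc1ccccc1-n1cc(-c2ccc(/C=C3\C(=O)Nc4ccccc43)cc2)nn1`: 9770 nM
Compound 2 `O=C1Nc2ccc(F)cc2C1=Cc1ccc(-c2cn(-c3ccccc3)nn2)cc1`: 11100 nM
Compound 3 `O=C1Nc2ccc(F)cc2/C1=C/c1ccc(-c2cn(-c3cccc(Cl)c3)nn2)cc1`: 14100 nM

In a functional assay on MKN-45 cells (Homo sapiens) for inhibition, read by CCK-8 assay, with a stated time of 24 h (on this read-out higher numbers stand for weaker inhibition and lower numbers for stronger inhibition), compound 2 gives 11100 nM. This value lies within the scatter of both neighbours, so compound 2 cannot be separated from compound 1 or from compound 3 on these numbers. All three sit together in one narrow band.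

The next compound to be tested is compound 4 `N#Cc1ccccc1-n1cc(-c2ccc(C=C3C(=O)Nc4ccc(F)cc43)cc2)nn1`. It is built from compound 2 by one change, cyano in place of hydrogen on an aromatic carbon, ortho to a large group, which turns phenyl into 2-cyanophenyl.

Within the data shown here, no pair of measured compounds differs in one place only, so the data hold no direct measure of this change. Among the measured compounds shown here, the only guide is the band itself: compound 1 at 9770 nM and compound 3 at 14100 nM remain within the scatter of each other although their structures differ in more than one place. In this assay no shift beyond the scatter is therefore expected. The estimated change is a 1.1-fold lower number from compound 2 to compound 4 (0.05 log units; within the scatter), and it is expected to be small. For compound 4 the estimated value is 10000 nM, with an expected range from 4500 nM to 22000 nM.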

Compound 4, half-maximal inhibitory concentration: 15200 nM
Compound 4: the middle estimate sits 1.5-fold (0.18 log units) below what was measured; measured number inside the range.
By their numbers in this assay, from the lowest: compounds 1, 2, 3 and 4 (each within the scatter of the next).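

With this step, the series has its first direct reading of a single change: in this assay cyano in place of hydrogen on an aromatic carbon, ortho to a large group, gives a 1.4-fold higher number from compound 2 to compound 4 (0.14 log units; within the scatter) and nothing more. At this position, then, turning phenyl into 2-cyanophenyl adds a nitrile with its triple bond and hydrogen-bond acceptor without moving the number beyond the usual scatter of the read-out, so this one step gives no sign that the change matters here. No measurement at hand accounts for this reading, and none bears on what the cyano group does at this position.

Going by these compounds, whether a different group on this same aromatic carbon, such as an amine, a carboxylic acid or a methoxy group, would give a step beyond the scatter remains open. On these data alone, it is equally open whether cyano would read the same on another carbon of this ring, or on a compound in which the fluorine of compound 2 is absent.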